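Bromine-bearing group in place of the group of compound 2

The compounds below may be only part of what the source reports. "The series", "measured", "known", "first", "only" and "open" are said of these compounds alone.

In a functional assay on SW-620 cells (Homo sapiens) for antiproliferative activity, read by MTT assay, with a stated time of 72 h (a lower number here means a stronger inhibitor, a higher number a weaker inhibitor), compound 1 (`O=C1O/C(=C\Cn2cnc3c(F)nc(F)c(Cl)c32)C(OCc2ccccc2)=C1OCc1ccccc1`) gives 55000 nM as its value. Compound 2 (`O=C1O/C(=C\Cn2cnc3cc[nH]c3c2=O)C(OCc2ccccc2)=C1OCc1ccccc1`) stands at > 100000 nM as a limit of the assay and not a number. Compound 3 (`O=C1O/C(=C\Cn2cnc3cncc(Br)c32)C(OCc2ccccc2)=C1OCc1ccccc1`) carries a group of 10 heavy atoms (6 carbon, 3 nitrogen, 1 bromine; one five-membered aromatic ring with 2 hetero atoms, one six-membered aromatic ring with 1 hetero atom) in place of a group of 10 heavy atoms (6 carbon, 3 nitrogen, 1 oxygen; one five-membered aromatic ring with 1 hetero atom, one six-membered aromatic ring with 2 hetero atoms), on a saturated chain carbon bound to a double-bonded chain carbon and so holds bromine where compound 2 holds none. Going by the values given here, the one measured step bearing on this is an at least 1.8-fold higher number from compound 1 to compound 2 (0.25 log units; that floor lies within the scatter) and it starts from a halogen-bearing group. For compound 3 the expected step is an at least 2.2-fold lower number from compound 2 to compound 3 (0.34 log units; beyond the scatter) and it is modest, toward a lower number. For compound 3 the estimated value is 45000 nM with an expected range of 12000 nM to 100000 nM for this measurement.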

Compound 3, half-maximal inhibitory concentration: 32900 nM
Compound 3: the middle estimate sits 1.4-fold (0.14 log units) above what was measured; low and high end bracket the measured number.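

In this assay, going by these compounds alone, the bromine-bearing group on the saturated chain carbon gives an at least 3.0-fold lower number from compound 2 to compound 3 (0.48 log units; beyond the scatter), the first change at this place that reaches beyond the scatter. That step is only a floor, since compound 2 stands at a limit and not a number: the limit of > 100000 nM in this assay, at which 1 of the 3 values shown sits. Against the group of compound 1, the same change gives a 1.7-fold lower number from compound 1 to compound 3 (0.22 log units; within the scatter), so these two halogen-bearing groups are not separated.

On these data alone, it remains open whether the bromine itself carries the step, as the rings change with it. An amine or a nitrile in place of the bromine would test this.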